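The compounds below may be only part of what the source reports. "The series", "measured", "known", "first", "only" and "open" are said of these compounds alone.

Compound 1 `CS(=O)(=O)c1cc(C(=O)N=C(N)N)ccc1-n1cccn1` gives 160 nM in a functional assay for inhibition of sodium/hydrogen exchanger (Oryctolagus cuniculus); a higher number here means a weaker inhibitor, a lower number a stronger inhibitor.
Compound 2 `CS(=O)(=O)c1cc(C(=O)N=C(N)N)ccc1C#N` gives 140 nM.
Compound 3 `Cc1cc(C#N)c(S(C)(=O)=O)cc1C(=O)N=C(N)N` gives 70 nM.

Compound 2 stands second highest of these three numbers, but both of its neighbours lie within the scatter: a 1.1-fold lower number from compound 1 to compound 2 (0.06 log units; within the scatter) and a 2.0-fold lower number from compound 2 to compound 3 (0.30 log units; within the scatter). Compound 4 `CS(=O)(=O)c1cc(C(=O)N=C(N)N)ccc1Cl` differs from compound 2 by chloro in place of cyano on an aromatic carbon. Within the data shown here, no measured step swaps cyano for chloro; the only step at that same place, swapping 1H-pyrazol-1-yl for cyano, gave a 1.1-fold lower number from compound 1 to compound 2 (0.06 log units; within the scatter), and the methyl step gave a 2.0-fold lower number from compound 2 to compound 3 (0.30 log units; within the scatter). Among the measured compounds shown here, with two small, in-scatter steps as the only guide, no step beyond the scatter is expected in this assay, that is a 1.1-fold higher number from compound 2 to compound 4 (0.03 log units; within the scatter). Compound 4 is therefore estimated at 150 nM, with a range from 60 nM to 350 nM.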

Compound 4, half-maximal inhibitory concentration: 380 nM
The estimate for compound 4 lay 2.5-fold (0.40 log units) below the measured number; the measured number lies above the stated range.
By their numbers in this assay, from the lowest: compounds 3, 2 and 1 (each within the scatter of the next, the first and the last beyond it); then compound 4.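

This position is not indifferent to its group after all: the swap between 1H-pyrazol-1-yl and cyano moved nothing beyond the scatter, whereas chloro brings a 2.7-fold higher number from compound 2 to compound 4 (0.43 log units; beyond the scatter) and a 2.4-fold higher number from compound 1 to compound 4 (0.38 log units; beyond the scatter) in this assay and so sets compound 4 apart from both. Cyano and 1H-pyrazol-1-yl stay level here, so the position does not accept every group alike. Nothing measured here explains why chloro stands apart.

Going by these compounds, whether an amine, a methoxy group or a carboxylic acid at this position would match cyano or chloro remains open. Also open, on these data alone, is whether the methyl group of compound 3 would act the same way alongside chloro.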